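The compounds below may be only part of what the source reports. "The series", "measured", "known", "first", "only" and "open" are said of these compounds alone.

Compound 1, `CCc1ccc2oc(CSc3nnc(CNc4ccccc4)n3CC)nc2c1`: in an assay on isolated protein for inhibition of long-chain fatty acid transport protein 1 (Homo sapiens) (a higher number here means a weaker inhibitor, a lower number a stronger inhibitor), compound 1 gives > 1000 nM, which is a limit of the assay rather than a number.
Compound 2, `CCn1c(CNc2ccccc2)nnc1SCC(=O)Nc1ccc(Cl)cc1`: in this assay compound 2 gives > 1000 nM, likewise a limit rather than a number.

Compound 2 therefore stands at the limit of this assay, without a number of its own, and the same holds for compound 1, as the limit of > 1000 nM in this assay, at which 2 of the 2 values shown sit, shows. Compound 3, `CCn1nnc(-c2ccc(NC(=O)CSc3nnc(CNc4ccccc4)n3CC)cc2)n1`, differs from compound 2 in one place: 2-ethyl-2H-tetrazol-5-yl in place of chloro on an aromatic carbon. Going by the values given here, no pair of measured compounds shows what such a change does in this assay, so there is no measured step to lean on, only the two limits. The step from compound 2 to compound 3 is therefore expected to be a step that the limit leaves unreadable from compound 2 to compound 3, that is, nothing clearly beyond the usual scatter in this assay, and most likely compound 3 will again end at a limit. On that basis compound 3 is estimated at 3000 nM, within a range from 700 nM to 20000 nM.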

Compound 3, half-maximal inhibitory concentration: > 1000 nM
Compound 3 ended at the assay's limit; the forecaster's own chance of this, stated with the estimate: 75%; the middle value lies beyond the limit too.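

No step can be read from compound 2 to compound 3, because both end at a limit rather than at a number: the limit of > 1000 nM in this assay, at which 3 of the 3 values shown sit. The compounds shown leave open how strongly each one inhibits in this assay, and whether 2-ethyl-2H-tetrazol-5-yl in place of chloro shifts that strength at all.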